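Trifluoromethyl in place of tert-butyl on compound 2

The compounds below may be only part of what the source reports. "The series", "measured", "known", "first", "only" and "open" are said of these compounds alone.

In a functional assay on HeLa cells (Homo sapiens) for cytotoxicity, read by MTT assay, with a stated time of 24 h (a lower number here means a stronger inhibitor, a higher number a weaker inhibitor), compound 1 (`COc1ccc(/C=C2\CN(C)C/C(=C\c3ccccc3F)C2=O)cc1`) gives 23500 nM and compound 2 (`CN1C/C(=C\c2ccc(C(C)(C)C)cc2)C(=O)/C(=C/c2ccccc2F)C1`) gives 15500 nM so the two sit within the scatter of each other. Compound 3 (`CN1C/C(=C\c2ccc(C(F)(F)F)cc2)C(=O)/C(=C/c2ccccc2F)C1`) is compound 2 with trifluoromethyl in place of tert-butyl on an aromatic carbon and has not been measured yet. Within the data shown here, the only measured step that bears on this swap is a 1.5-fold lower number from compound 1 to compound 2 (0.18 log units; within the scatter) for tert-butyl in place of methoxy, so no step beyond the scatter is expected in this assay here. The expected size is an estimated 1.1-fold lower number from compound 2 to compound 3 (0.04 log units; within the scatter) and nothing larger. Compound 3 is estimated at 14000 nM with 6000 nM to 30000 nM as its expected range.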

Compound 3, half-maximal inhibitory concentration: 6560 nM
Beside the measured number, compound 3's estimate is 2.1-fold (0.33 log units) above it; low and high end bracket the measured number.
By their numbers in this assay, from the lowest: compound 3; then compounds 2 and 1 (each within the scatter of the next).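

In this assay this aromatic carbon now shows a clear response to its group: trifluoromethyl brings a 2.4-fold lower number from compound 2 to compound 3 (0.37 log units; beyond the scatter) and a 3.6-fold lower number from compound 1 to compound 3 (0.55 log units; beyond the scatter) while methoxy and tert-butyl stayed within the scatter of each other. Tert-butyl and trifluoromethyl each have 4 heavy atoms, so that count alone does not set the number here. Nothing measured here explains the lower number. As far as these compounds go, whether an amine or a carboxylic acid on this carbon would lower the number further stays open. Also open, from the compounds shown here alone, is whether the same swap would give a similar step on a different core.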